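This account rests on a few compounds, and the source may have more. Where it says the series, first, only, none or still open, it means among the compounds named here.

Compound 1 `COc1cccc(C(=O)Oc2ccc3c(=O)c(-c4cc(OC)c(OC)cc4OC)coc3c2)c1`: > 10000 nM, a limit of the assay
Compound 2 `COc1cc(OC)c(-c2coc3cc(OCc4ccc(C#N)cc4)ccc3c2=O)cc1OC`: 6180 nM

Among the compounds with values here, in a functional assay on U-251 cells (Homo sapiens) for antiproliferative activity, read by MTT assay, with a stated time of 24 h (a lower number here means a stronger inhibitor, a higher number a weaker inhibitor), compound 2 at 6180 nM holds the only true number so far. Compound 3 `COc1cc(OC)c(-c2coc3cc(OCc4ccccc4Cl)ccc3c2=O)cc1OC` changes one group of compound 2: 2-chlorophenyl in place of 4-cyanophenyl on a saturated chain carbon bound to an oxygen on an aromatic ring. Here 2-chlorophenyl stands in place of 4-cyanophenyl on a saturated chain carbon bound to an oxygen on an aromatic ring. Within the data shown here, the one measured step, also on that oxygen, is an at least 1.6-fold lower number from compound 1 to compound 2 (0.20 log units; that floor lies within the scatter). It gives only a floor because of the limit of > 10000 nM in this assay, at which 1 of the 2 values shown sits. No change beyond the scatter is therefore expected, in either direction. The estimated 1.0-fold lower number from compound 2 to compound 3 (0.01 log units; within the scatter) stays small. For compound 3 the expected value is 6000 nM, with an estimated range of 2500 nM to 10000 nM.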

Compound 3, half-maximal inhibitory concentration: > 10000 nM
Compound 3: only a limit was reported (the forecaster's own chance of this, stated with the estimate: 30%); at least 1.6-fold (0.22 log units) between middle value and limit.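

With 2-chlorophenyl in place of 4-cyanophenyl on a saturated chain carbon bound to an oxygen on an aromatic ring, this assay gives an at least 1.6-fold higher number from compound 2 to compound 3 (0.20 log units; that floor lies within the scatter). As far as these compounds go, compound 3 reaches only a limit of the assay, so a substituted benzyl group on this oxygen does not by itself ensure a true number, and the size of this change stays unknown. The step from compound 1 to compound 3 cannot be read, and compound 2 remains the only compound with a true number: the limit of > 10000 nM in this assay, at which 2 of the 3 values shown sit.

From the compounds shown here alone, it remains open how a benzyl group carrying an amine or a carboxylic acid would read here. A longer chain between the oxygen and the ring is equally untested among the compounds shown.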